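This account rests on a few compounds, and the source may have more. Where it says the series, first, only, none or still open, it means among the compounds named here.

Three compounds share a common core in which a sulfonamide carries an aryl group on its nitrogen. Compound 1 `CCc1ccccc1NS(=O)(=O)c1ccc(N2CCNC2=O)cc1` gives 240 nM in a functional assay on HT-29 cells (Homo sapiens) for antiproliferative activity, read by sulforhodamine B assay, with a stated time of 48 h; on this read-out lower numbers stand for stronger inhibition and higher numbers for weaker inhibition. Compound 2 `CCc1ccc(NS(=O)(=O)c2ccc(N3CCNC3=O)cc2)cc1` gives 660 nM in this assay, and compound 3 `COc1cccc(NS(=O)(=O)c2ccc(N3CCNC3=O)cc2)c1` gives 120 nM. Compound 2 stands highest of the three: a 2.8-fold higher number from compound 1 to compound 2 (0.44 log units; beyond the scatter), and a 5.5-fold lower number from compound 2 to compound 3 (0.74 log units; beyond the scatter), both steps beyond the scatter. Compound 4 `CCCCCCOc1ccc(NS(=O)(=O)c2ccc(N3CCNC3=O)cc2)cc1` has not yet been measured. It differs from compound 2 by hexyloxy in place of ethyl on an aromatic carbon, the new group sitting on an aromatic carbon of a six-membered aromatic ring of carbon only, para to a large group. The measured steps touch the same ring but not the same change: the step of a 2.8-fold higher number from compound 1 to compound 2 (0.44 log units; beyond the scatter) exchanged 2-ethylphenyl for 4-ethylphenyl, and the step of a 5.5-fold lower number from compound 2 to compound 3 (0.74 log units; beyond the scatter) exchanged 4-ethylphenyl for 3-methoxyphenyl. Going by the values given here, no measured step bears on swapping ethyl for hexyloxy, so the number of compound 2 is the only firm anchor and the range must be wide. Compound 4 is expected to give 900 nM, between 250 nM and 3200 nM. That estimate means a 1.4-fold higher number from compound 2 to compound 4 (0.13 log units; within the scatter), a change not clearly beyond the scatter.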

Compound 4, half-maximal inhibitory concentration: > 1000 nM
Compound 4: no number, only a limit (the forecaster's own chance of this, stated with the estimate: 5%); middle value at least 1.1-fold (0.04 log units) from the limit.
By their numbers in this assay, from the lowest: compounds 3 and 1 (each within the scatter of the next); then compound 2. At a limit, above all of these: compound 4.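

In this assay, compound 4 has no number but a limit of the assay: the limit of > 1000 nM in this assay, at which 1 of the 4 values shown sits. The earlier steps shown here all changed the place of the group on the ring, whereas this one keeps the place, on an aromatic carbon para to a large group, and changes only the group. Hexyloxy in place of ethyl gives an at least 1.5-fold higher number from compound 2 to compound 4 (0.18 log units; that floor lies within the scatter), so this change shows no gain at this place, although its floor does not establish a loss beyond the scatter.

From the compounds shown here alone, the size of the step stays open, since the limit does not give a number for compound 4. Also open, going by these compounds, is how a shorter ether such as propyloxy, an amine or a carboxylic acid at this place would compare with the ethyl of compound 2.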